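This account rests on a few compounds, and the source may have more. Where it says the series, first, only, none or still open, it means among the compounds named here.

Measured so far:
- compound 1, `O=C(CCSc1nc2cc(Cl)ccc2o1)N1CCC1`, 17.9 mL/min/g
- compound 2, `O=C(CCSc1nc2cc(Cl)ccc2o1)N1CCCCC1`, 128 mL/min/g
- compound 3, `CN1CCN(C(=O)CCSc2nc3cc(Cl)ccc3o2)CC1`, 41.5 mL/min/g

All three share one core and differ only in the ring attached to the carbonyl carbon. In an ADME assay on microsomes from liver (Mus musculus) for metabolic stability, read by LC-MS, using NADPH, with a stated time of 45 min, tested at 0.5 uM (a lower number here means slower removal, a higher number faster removal of the compound), compound 3 stands second highest of the three numbers: the step of a 2.3-fold higher number from compound 1 to compound 3 (0.37 log units; beyond the scatter) places it well above compound 1, and the step of a 3.1-fold lower number from compound 2 to compound 3 (0.49 log units; beyond the scatter) places it well below compound 2, both beyond the scatter.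

Compound 4, `CC1CCCN1C(=O)CCSc1nc2cc(Cl)ccc2o1`, has not yet been measured. It differs from compound 3 in one place: 2-methylpyrrolidin-1-yl in place of 4-methylpiperazin-1-yl on a carbonyl carbon.

Within the data shown here, two measured steps bear on this change. The step of a 7.2-fold higher number from compound 1 to compound 2 (0.85 log units; beyond the scatter) shows that a larger saturated ring holding a single nitrogen gave a markedly higher number than the smallest such ring. The step of a 3.1-fold lower number from compound 2 to compound 3 (0.49 log units; beyond the scatter) shows that a ring with a second nitrogen gave a lower number than the ring with one. Compound 4 carries a five-membered ring with one nitrogen, so a rise in this assay from compound 3 seems the more likely direction, though its size is uncertain. The expected step is a 2.0-fold higher number from compound 3 to compound 4 (0.31 log units; beyond the scatter), and compound 4 is therefore estimated at 85 mL/min/g, with a range from 35 mL/min/g to 220 mL/min/g.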

Compound 4, intrinsic clearance in a liver preparation (reported as CLH), per the amount of preparation that the assay uses: 98 mL/min/g
Estimate against measurement, compound 4: 1.2-fold (0.06 log units) below, within the range that was stated.
By their numbers in this assay, from the lowest: compound 1; then compound 3; then compounds 4 and 2 (each within the scatter of the next).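

In this assay, the move away from the 4-methylpiperazin-1-yl ring is a 2.4-fold higher number from compound 3 to compound 4 (0.37 log units; beyond the scatter), so a five-membered ring with one nitrogen and a methyl group, 2-methylpyrrolidin-1-yl, also gives a number well above that of the ring with two nitrogens. Compared with the six-membered piperidin-1-yl ring, the result is a 1.3-fold lower number from compound 2 to compound 4 (0.12 log units; within the scatter), so these two different rings cannot be told apart in this assay, whereas a 5.5-fold higher number from compound 1 to compound 4 (0.74 log units; beyond the scatter) keeps both clearly separate from the azetidin-1-yl ring, which goes against any simple link between a single ring nitrogen and a high number. Nothing presented here explains these differences.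

The compounds shown leave open how much of this result belongs to the five-membered ring and how much to its methyl group, a question that a plain pyrrolidin-1-yl group would help to separate. Also open is where a six-membered ring holding an oxygen, morpholin-4-yl, would fall relative to the rings shown here.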